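The source may hold more compounds than are shown below. What is called first, only, known or untested is meant among the compounds shown, and "the series" means these compounds.

Within the data shown here, in a functional assay for inhibition, with Homo sapiens as the target (on this read-out lower numbers stand for stronger inhibition and higher numbers for weaker inhibition), compound 2 `CC(C)(C)Sc1c(CC(C)(C)C(=O)O)n(Cc2ccc(Cl)cc2)c2ccc(OCc3ccc4cc(F)ccc4n3)cc12` gives 2 nM, the only plain number among the two values shown. Compound 1 `CCCC(Oc1ccc2c(c1)c(SC(C)(C)C)c(CC(C)(C)C(=O)O)n2Cc1ccc(Cl)cc1)c1ccc2ccccc2n1` yields only a limit in this assay, > 52 nM, and the limit of > 52 nM in this assay, at which 1 of the 2 values shown sits, records that limit. Compound 3 `CC(C)(C)Sc1c(CC(C)(C)C(=O)O)n(Cc2ccc(Cl)cc2)c2ccc(OCc3ccc4cccnc4n3)cc12` is not yet measured; it differs from compound 2 by a group of 10 heavy atoms (8 carbon, 2 nitrogen; 2 six-membered aromatic rings with 1 hetero atom each) in place of a group of 11 heavy atoms (9 carbon, 1 nitrogen, 1 fluorine; one six-membered aromatic ring of carbon only, one six-membered aromatic ring with 1 hetero atom), on a saturated chain carbon bound to an oxygen on an aromatic ring. Among the measured compounds shown here, no step between measured compounds is available to lean on, so compound 3 is expected to lose only a little in this assay, at most a shade beyond the usual scatter. Compound 3 is estimated at 4 nM (between 1.5 nM and 12 nM), which means a step of a 2.0-fold higher number from compound 2 to compound 3 (0.30 log units; within the scatter).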

Compound 3, half-maximal inhibitory concentration: 6 nM
Beside the measured number, compound 3's estimate is 1.5-fold (0.18 log units) below it; measured number inside the range.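

In this assay, among these compounds, the change shows a step of a 3.0-fold higher number from compound 2 to compound 3 (0.48 log units; beyond the scatter), the first step that can be read at this place, on a saturated chain carbon bound to an oxygen on an aromatic ring. Replacing 6-fluoroquinolin-2-yl costs a modest amount, beyond the scatter, and compound 3 still gives 6 nM. Nothing measured here accounts for this step. The compounds shown do not separate the loss of the fluorine from the gain of the ring nitrogen. On these data alone, how a chloro or methoxy group in the fluorine's stead would read in this assay remains open.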